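Ether chain changes on the shared core

A few compounds are considered here, and "the series" means these few. Any claim that something is new, unique, unknown or untested is made for them only; others in the source may bear on it.

Measured in a functional assay on PC-3 cells (Homo sapiens) for antiproliferative activity, read by WST assay, with a stated time of 3 days; a higher number here means a weaker inhibitor, a lower number a stronger inhibitor
- compound 1 `CCCCOc1c(-c2cc(OC)c(OC)c(OC)c2)oc2ccccc2c1=O` gives 12800 nM
- compound 2 `CCCC(C)Oc1c(-c2cc(OC)c(OC)c(OC)c2)oc2ccccc2c1=O` gives 49300 nM
- compound 3 `CCN(CC)CCCOc1c(-c2cc(OC)c(OC)c(OC)c2)oc2ccccc2c1=O` is not yet measured

Compound 2 has the higher of the two numbers. The next change is 3-(diethylamino)propyl in place of 1-methylbutyl on an oxygen on an aromatic ring with 3-(diethylamino)propyl in place of 1-methylbutyl on an oxygen on an aromatic ring. Within the data shown here, the one measured step bearing on this is a 3.9-fold higher number from compound 1 to compound 2 (0.59 log units; beyond the scatter) and compound 3, like compound 1, lacks that methyl. Among the measured compounds shown here, no measured compound carries the amine chain, so the expectation is loose. A modest move to a lower number in this assay is expected, with an estimated 5.5-fold lower number from compound 2 to compound 3 (0.74 log units; beyond the scatter) as its size. The estimate for compound 3 is 9000 nM (2000 nM to 35000 nM).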

Compound 3, half-maximal inhibitory concentration: 13600 nM
The estimate for compound 3 lay 1.5-fold (0.18 log units) below the measured number; low and high end bracket the measured number.
By their numbers in this assay, from the lowest: compounds 1 and 3 (each within the scatter of the next); then compound 2.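

In this assay, diethylamino in place of methyl on a saturated chain carbon, three bonds along the chain from the oxygen on the aromatic ring, gives a 1.1-fold higher number from compound 1 to compound 3 (0.03 log units; within the scatter), so this position accepts an amine without a change beyond the scatter. 3-(Diethylamino)propyl in place of 1-methylbutyl gives a 3.6-fold lower number from compound 2 to compound 3 (0.56 log units; beyond the scatter), so the unbranched amine chain reads better than the branched carbon chain. No measured data explain either step. Still open, from the compounds shown here alone, is whether a shorter or longer chain carrying the amine, or a morpholine or pyrrolidine in place of diethylamino, would move the number.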